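The compounds below may be only part of what the source reports. "The series", "measured", "known", "first", "only" and "open" are said of these compounds alone.

For the measured compounds named here, compound 2 `O=C1NC(=O)/C(=C\c2ccc(OCC(=O)N3N=C(c4ccccc4)CC3c3ccc(C(F)(F)F)cc3)cc2)S1` gives 1000 nM in an assay on cells for inhibition of histone deacetylase 4 (Homo sapiens), read by fluorescence, with a stated time of 30 min (a higher number here means a weaker inhibitor, a lower number a stronger inhibitor), the lowest of the three numbers so far. Compound 1 `O=C1NC(=O)/C(=C\c2ccc(OCC(=O)N3N=C(c4ccccc4)CC3c3ccccc3)cc2)S1` gives 1600 nM, and the step of a 1.6-fold lower number from compound 1 to compound 2 (0.20 log units; within the scatter) stays within the scatter. Compound 3 `O=C1NC(=O)/C(=C\c2ccc(OCC(=O)N3N=C(c4ccccc4)CC3c3ccc(F)cc3F)cc2)S1` gives 2200 nM, and the step of a 2.2-fold higher number from compound 2 to compound 3 (0.34 log units; beyond the scatter) is modest. Compound 4 `Cc1ccc(C2CC(c3ccccc3)=NN2C(=O)COc2ccc(/C=C3/SC(=O)NC3=O)cc2)cc1` differs from compound 2 by methyl in place of trifluoromethyl on an aromatic carbon. The closest guide is the step of a 1.6-fold lower number from compound 1 to compound 2 (0.20 log units; within the scatter), which put trifluoromethyl in where hydrogen had been and moved the number only within the scatter; taking that group out again and leaving methyl is therefore expected to move the number little, if at all. Compound 4 is expected to give about 1300 nM, with a range of 700 nM to 2500 nM, a step of a 1.3-fold higher number from compound 2 to compound 4 (0.11 log units; within the scatter) that is expected to stay within the scatter.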

Compound 4, half-maximal inhibitory concentration: 1200 nM
Compound 4: the middle estimate sits 1.1-fold (0.03 log units) above what was measured, within the range that was stated.
By their numbers in this assay, from the lowest: compounds 2, 4, 1 and 3 (each within the scatter of the next, the first and the last beyond it).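

On the aromatic ring, para to a large group, replacing trifluoromethyl with methyl removes three fluorine atoms yet leaves the number within the scatter in this assay (a 1.2-fold higher number from compound 2 to compound 4 (0.08 log units; within the scatter)), and methyl in place of hydrogen does the same (a 1.3-fold lower number from compound 1 to compound 4 (0.12 log units; within the scatter)). Compound 4 also stays within the scatter of the 2,4-difluorophenyl compound (a 1.8-fold lower number from compound 3 to compound 4 (0.26 log units; within the scatter)). No measurement here explains why these groups read so alike.

As far as these compounds go, it remains open whether an amine, a carboxylic acid or a longer chain at this position would move the number beyond the scatter.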